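The compounds below may be only part of what the source reports. "The series", "measured", "known", "first", "only" and "open" are said of these compounds alone.

Measured so far in a functional assay on HT-29 cells (Homo sapiens) for antiproliferative activity, read by MTT assay, with a stated time of 72 h, tested at 10 uM; on this read-out higher numbers stand for more inhibition at the one concentration tested (going by the name of the read-out) and lower numbers for less inhibition:

compound 1, `O=C(Nc1cc(Oc2ccc(Nc3nccc4[nH]cc(-c5ccc(F)cc5)c(=O)c34)cc2F)ccn1)C1CCC1` — 46%
compound 2, `CCn1cc(-c2ccc(F)cc2)c(=O)c2c(Nc3ccc(Oc4ccnc(NC(=O)C5CC5)c4)c(F)c3)nccc21` — 15.8%
compound 3, `CC(O)C(=O)Nc1cc(Oc2ccc(Nc3nccc4[nH]cc(-c5ccc(F)cc5)c(=O)c34)cc2F)ccn1` — 47.8%

Compound 3 gives the highest of the three numbers in this assay, but its lead over compound 1 is small: the step of a number 1.8 percentage points higher from compound 1 to compound 3 (within the scatter) lies within the scatter, so the two cannot be ordered. Going by the values given here, compound 2, which carries an ethyl on the ring nitrogen of the shared core, a cyclopropyl on the carbonyl and a different arrangement of the fluorine-bearing ring, sits far lower, a gap beyond the scatter; no single-point step connects it to compound 3.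

Compound 4, `CCCCC(=O)Nc1cc(Oc2ccc(Nc3nccc4[nH]cc(-c5ccc(F)cc5)c(=O)c34)cc2F)ccn1`, differs from compound 3 only at the carbonyl carbon: butyl in place of 1-hydroxyethyl on a carbonyl carbon. Among the compounds with values here, the one measured step that bears on this position is a number 1.8 percentage points higher from compound 1 to compound 3 (within the scatter), where cyclobutyl and 1-hydroxyethyl gave numbers within the scatter of each other. Two rather different groups on that carbonyl thus left this assay essentially unchanged, so a third, butyl, is expected to do the same; no direction beyond the scatter is anticipated, and the expected step is a number 2.8 percentage points lower from compound 3 to compound 4 (within the scatter).

Compound 4 is therefore estimated at 45%, with a range from 30% to 60%.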

Compound 4, a percentage reported as inhibition, at one concentration (the size of the read-out at that concentration, not a potency): -42.2%
The estimate for compound 4 lay 87.2 percentage points above the measured number, outside the stated range (below it).
By their numbers in this assay, from the lowest: compound 4; then compound 2; then compounds 1 and 3 (each within the scatter of the next).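

In this assay the group on the carbonyl carbon is not the neutral place that compound 1 and compound 3 made it seem: butyl gives a number 90 percentage points lower from compound 3 to compound 4 (beyond the scatter), and against the ring-bearing partner it gives a number 88.2 percentage points lower from compound 1 to compound 4 (beyond the scatter). Among these three compounds with the shared core, a hydroxyl on an open chain and a ring without a hydroxyl both keep the number at the same level, while compound 4, whose group has neither, gives a number below zero on a read-out of inhibition, so the outcome at this place depends on the group's identity and not merely on a carbonyl substituent being present. Nothing measured at hand accounts for this fall.

Open, on these data alone, is whether the fall belongs to butyl alone or to open carbon chains in general, which a propyl, a pentyl or a longer chain would test. Also open, as far as these compounds go, is whether a hydroxyl, an amine or a carboxylic acid at the end of the butyl chain would bring the number back to the level of compound 3.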